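Methoxy for bromo on the sulfonyl arm

A few compounds are considered here, and "the series" means these few. Any claim that something is new, unique, unknown or untested is made for them only; others in the source may bear on it.

The series keeps one shared core and varies the group on the ring nitrogen. Compound 1 `CN(C(=O)c1ccc(Br)cc1)c1ccc2[nH]c(-c3n[nH]c4ccccc34)cc2n1` carries a (4-bromophenyl)carbonyl there; in a functional assay on SMMC-7721 cells (Homo sapiens) for antiproliferative activity, read by MTT assay, with a stated time of 72 h (a higher number here means a weaker inhibitor, a lower number a stronger inhibitor), compound 1 gives 3460 nM. Compound 2 `COc1ccc(C(=O)N(C)c2ccc3[nH]c(-c4n[nH]c5ccccc45)cc3n2)cc1` differs from compound 1 by methoxy in place of bromo on an aromatic carbon, and in this assay compound 2 gives 23700 nM, a step of a 6.8-fold higher number from compound 1 to compound 2 (0.84 log units; beyond the scatter). Compound 3 `CN(c1ccc2[nH]c(-c3n[nH]c4ccccc34)cc2n1)S(=O)(=O)c1ccc(Br)cc1` differs from compound 1 by (4-bromophenyl)sulfonyl in place of (4-bromophenyl)carbonyl on a nitrogen on an aromatic ring; in this assay compound 3 gives 11500 nM, which amounts to a 3.3-fold higher number from compound 1 to compound 3 (0.52 log units; beyond the scatter). Set against compound 2, the step is a 2.1-fold lower number from compound 2 to compound 3 (0.31 log units; beyond the scatter).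

Compound 4 `COc1ccc(S(=O)(=O)N(C)c2ccc3[nH]c(-c4n[nH]c5ccccc45)cc3n2)cc1` is not yet measured. It differs from compound 3 by methoxy in place of bromo on an aromatic carbon. This is the change already made from compound 1 to compound 2, where it gave a 6.8-fold higher number from compound 1 to compound 2 (0.84 log units; beyond the scatter); the place is described in the same words both times, so it counts as the same change, here carried on a core that differs by (4-bromophenyl)sulfonyl in place of (4-bromophenyl)carbonyl on a nitrogen on an aromatic ring. Going by the values given here, only one earlier instance exists, and the core is not identical, so the transfer rests on a single step. For compound 4 the expected step is a 5.2-fold higher number from compound 3 to compound 4 (0.72 log units; beyond the scatter), because the same change gave a 6.8-fold higher number from compound 1 to compound 2 (0.84 log units; beyond the scatter). Compound 4 is therefore estimated at 60000 nM, with a range from 25000 nM to 150000 nM.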

Compound 4, half-maximal inhibitory concentration: 13000 nM
Beside the measured number, compound 4's estimate is 4.6-fold (0.66 log units) above it; the whole stated range lies above it.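

Methoxy for bromo on the sulfonyl arm

In this assay the step on the sulfonyl arm is a 1.1-fold higher number from compound 3 to compound 4 (0.05 log units; within the scatter) and so lies within the scatter, which means the two sulfonyl compounds cannot be told apart on this read-out. This shows that methoxy in place of bromo does not bring a fixed size of step from the carbonyl arm to the sulfonyl arm in this series, so a step read on one arm is a poor guide to the other; it does not show why the two arms part, nor which of the two steps is the more usual one, as the comparison rests on a single pair from each arm. The two steps, set side by side, read as follows: the same change on two cores in this assay, a 6.8-fold higher number (0.84 log units; beyond the scatter) from compound 1 to compound 2 and a 1.1-fold higher number (0.05 log units; within the scatter) from compound 3 to compound 4, 6.1-fold (0.78 log units) apart, beyond the scatter of two such steps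

The compounds shown hold only bromo and methoxy on the aromatic carbon, and only carbonyl and sulfonyl on the nitrogen on the aromatic ring, so two pairs are all that bear on the question. As far as these compounds go, whether an amine or a carboxylic acid in place of bromo would give a large step on the carbonyl arm and a small one on the sulfonyl arm, as methoxy does, stays open, as does whether the gap between the arms holds in any other cell line.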